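A few compounds are considered here, and "the series" means these few. Any claim that something is new, unique, unknown or untested is made for them only; others in the source may bear on it.

Compound 3 `COc1ccc(CN2CCC(C(=O)Nc3cc(Cl)c(N)cc3OC)CC2)cc1` is the point of reference. Among the measured compounds shown here, in a functional assay on the whole organism for antagonist activity, with Mus musculus as the target (a lower number here means that less compound is needed, a higher number that more compound is needed for the effect), compound 3 gives 0.9 mg/kg, the only outright number among the three values shown. Compound 1 `CCCCCCN1CCC(C(=O)Nc2cc(Cl)c(N)cc2OC)CC1` reaches only a limit of this assay, > 10 mg/kg. Compound 2 `CCCCN1CCC(C(=O)Nc2cc(Cl)c(N)cc2OC)CC1` likewise stops at a limit of this assay, > 10 mg/kg. The picture is thus dominated by the limit of > 10 mg/kg in this assay, at which 2 of the 3 values shown sit. The steps from those two compounds to compound 3 read an at least 11-fold lower number from compound 1 to compound 3 (1.04 log units; beyond the scatter) and an at least 11-fold lower number from compound 2 to compound 3 (1.04 log units; beyond the scatter), both beyond the scatter, and both put 4-methoxyphenyl where a plain chain had been.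

The move to compound 4 `COc1cc(N)c(Cl)cc1NC(=O)C1CCN(Cc2ccsc2)CC1` is of a different kind: thiophen-3-yl in place of 4-methoxyphenyl on a saturated chain carbon bound to an amine nitrogen in a ring, so one aromatic ring gives way to another. For the measured compounds named here, no measured step covers such an exchange; the two steps that exist show only that an aromatic group in this place does far better than a chain. Compound 4 is therefore expected to show no more than a 1.7-fold higher number from compound 3 to compound 4 (0.22 log units; within the scatter) in this assay. The estimate for compound 4 is 1.5 mg/kg, in a range from 0.6 mg/kg to 4 mg/kg.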

Compound 4, dose for half-maximal effect: 3.4 mg/kg
Compound 4: middle estimate off by 2.3-fold (0.36 log units), on the low side; measured number inside the range.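

In this assay, the exchange of one aromatic ring for another at this position is not silent: thiophen-3-yl in place of 4-methoxyphenyl gives a 3.8-fold higher number from compound 3 to compound 4 (0.58 log units; beyond the scatter), so the identity of the aromatic group counts here, not only its presence. Thiophen-3-yl nevertheless still does better than either plain chain, with an at least 2.9-fold lower number from compound 2 to compound 4 (0.46 log units; beyond the scatter) and an at least 2.9-fold lower number from compound 1 to compound 4 (0.46 log units; beyond the scatter). Both of these steps are minimum sizes only, because the two chain compounds rest on a limit: the limit of > 10 mg/kg in this assay, at which 2 of the 4 values shown sit.

The two aromatic groups differ both in the ring and in the methoxy group, so the compounds shown do not separate the two changes. On these data alone, how a plain phenyl, a thiophen-2-yl or a pyridine ring would read in this place stays open.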